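Swapping trifluoromethyl for cyano: stability of compound 4

This account rests on a few compounds, and the source may have more. Where it says the series, first, only, none or still open, it means among the compounds named here.

Compound 1 `Nc1ncnc2c1c(Oc1cc(C(F)(F)F)ccn1)nn2C1CC1`: > 2.41 h (a limit)
Compound 2 `Nc1ncnc2c1c(Oc1cc(C(F)(F)F)ccn1)nn2[C@H]1CC[C@@H](CO)CC1`: 1.6 h
Compound 3 `Nc1ncnc2c1c(Oc1cc(C(F)(F)F)ccn1)nn2[C@H]1C[C@H](F)C1`: 2.03 h

In an ADME assay on microsomes from liver (Homo sapiens) for metabolic stability, read by LC-MS, using NADPH, with a stated time of 10 min, tested at 10 uM (a lower number here means that the compound disappears faster, a higher number that the compound lasts longer), compound 1 gives only a limit, not a number: the limit of > 2.41 h in this assay, at which 1 of the 3 values shown sits.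

Compound 4 `N#Cc1ccnc(Oc2nn(C3CC3)c3ncnc(N)c23)c1` keeps the core of compound 1 and changes one group: cyano in place of trifluoromethyl on an aromatic carbon. The change sits opposite the ring nitrogen.

For the measured compounds named here, no measured step touches that place. The available steps change the group on an aromatic nitrogen instead: an at least 1.5-fold lower number from compound 1 to compound 2 (0.17 log units; that floor lies within the scatter), an at least 1.1-fold lower number from compound 1 to compound 3 (0.07 log units; that floor lies within the scatter) and a 1.3-fold higher number from compound 2 to compound 3 (0.10 log units; within the scatter). Their sizes or floors all lie within the scatter, so they offer only a weak guide.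

No step beyond the scatter is expected, in either direction, and the estimated step is an at least 1.0-fold lower number from compound 1 to compound 4 (0.02 log units; that floor lies within the scatter).

Compound 4 is expected at 2.3 h, with an estimated range from 1.1 h to 4.5 h.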

Compound 4, half-life: > 2.41 h
Compound 4: a limit, no number (the forecaster's own chance of this, stated with the estimate: 40%); middle value at least 1.0-fold (0.02 log units) from the limit.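

In this assay, compound 1 and compound 4 both give a limit rather than a number, so the step between them cannot be read: the limit of > 2.41 h in this assay, at which 2 of the 4 values shown sit.

As far as these compounds go, whether cyano in place of trifluoromethyl changes the half-life at all, and in which direction, stays open.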